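Cyano in Place of Hydrogen on Compound 2

The source may report more compounds than this note shows. Statements on the series, on what has been measured and on what is new or still open speak of the compounds shown alone.

Of the compounds shown here, two have so far been measured in a functional assay on HUVEC cells (Homo sapiens) for inhibition, with a stated time of 4 days (on this read-out higher numbers stand for weaker inhibition and lower numbers for stronger inhibition), as the only evidence. Compound 1 (`COc1ccc(C#N)cc1COc1ccc(Cl)c(C)c1`) gives 1500 nM there, and compound 2 (`COc1ccc(C(N)=O)cc1/C=C/c1ccccc1`) gives 2400 nM there. These two numbers lie within the usual scatter of each other, so compound 2 cannot be ranked against compound 1 on this evidence. Compound 3 (`COc1ccc(C(N)=O)cc1/C=C/c1ccc(C#N)cc1`) is compound 2 with cyano in place of hydrogen on an aromatic carbon, para to a large group (cyano in place of hydrogen on an aromatic carbon). Among the measured compounds shown here, no step between measured compounds shows what such a change does in this assay and the two values offer no guide to its direction. The size expected is therefore none beyond the scatter, with only a slight lean towards a lower number. The estimated change is a 1.3-fold lower number from compound 2 to compound 3 (0.12 log units; within the scatter) and is expected to stay within that scatter. For compound 3 the estimate is 1800 nM as the expected result, with an expected range from 500 nM to 6000 nM when it is measured.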

Compound 3, half-maximal inhibitory concentration: 3100 nM
Beside the measured number, compound 3's estimate is 1.7-fold (0.24 log units) below it; low and high end bracket the measured number.
By their numbers in this assay, from the lowest: compounds 1, 2 and 3 (each within the scatter of the next, the first and the last beyond it).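

In this assay, the step with cyano in place of hydrogen on an aromatic carbon, para to a large group, is a 1.3-fold higher number from compound 2 to compound 3 (0.11 log units; within the scatter), so compound 2 and compound 3 cannot be told apart on this read-out. Among the compounds shown here, this is the first direct reading of any change at this position, and it shows that this position can carry a cyano, with its 2 heavy atoms and 1 hydrogen-bond acceptor, without a shift beyond the scatter. Nothing shown here gives a reason for this result.

As far as these compounds go, what remains open is whether this insensitivity belongs to the position or only to cyano, since a single substituent cannot separate the two. An amine, a carboxylic acid or a longer chain such as propyl at the same place could show whether the read-out stays within the scatter for groups of other kinds and sizes, or whether this position has a limit that cyano does not reach.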